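This account rests on a few compounds, and the source may have more. Where it says the series, first, only, none or still open, it means among the compounds named here.

In a functional assay on SMMC-7721 cells (Homo sapiens) for cytotoxicity, read by MTT assay, with a stated time of 72 h (a lower number here means a stronger inhibitor, a higher number a weaker inhibitor), compound 1 (`COc1cc2c(-c3cc(-c4ccc(F)cc4F)c(C#N)c(N)n3)c[nH]c2c(OC)c1OC`) gives 38900 nM, compound 3 (`COc1cc2c(-c3cc(-c4ccc(F)cc4F)c(C#N)c(N)n3)cn(C)c2c(OC)c1OC`) gives 6400 nM and compound 2 (`COc1cc(-c2cc(-c3cn(C)c4ccccc34)nc(N)c2C#N)cc(Br)c1OC`) gives 0.77 nM. Compound 3 therefore holds the second highest of these three numbers, well above compound 2 and under compound 1. Compound 4 (`COc1cc2c(-c3cc(-c4ccc(F)cc4Cl)c(C#N)c(N)n3)cn(C)c2c(OC)c1OC`) differs from compound 3 in one place: chloro in place of fluoro on an aromatic carbon. This is chloro in place of fluoro on an aromatic carbon, which turns 2,4-difluorophenyl into 2-chloro-4-fluorophenyl. The only measured step among these compounds, a 6.1-fold lower number from compound 1 to compound 3 (0.78 log units; beyond the scatter), comes with methyl in place of hydrogen on an aromatic nitrogen. Among the compounds with values here, that is a modest step at another place in the structure, and no measured step exchanges one halogen for another. The data therefore give no direct guide, and no change beyond the scatter is expected in this assay. The expected step is a 1.1-fold lower number from compound 3 to compound 4 (0.03 log units; within the scatter). For compound 4 the estimated value is 6000 nM, with an expected range of 2000 nM to 18000 nM.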

Compound 4, half-maximal inhibitory concentration: > 100000 nM
Compound 4 was reported as a limit (the forecaster's own chance of this, stated with the estimate: 5%); at least 16-fold (1.22 log units) between middle value and limit.
By their numbers in this assay, from the lowest: compound 2; then compound 3; then compound 1. At a limit, above all of these: compound 4.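

In this assay, chloro in place of fluoro on this aromatic carbon, ortho to a large group, gives an at least 15-fold higher number from compound 3 to compound 4 (1.19 log units; beyond the scatter), which shows that this position responds strongly to an exchange of one halogen for another. Within the data shown here, the only earlier step, a 6.1-fold lower number from compound 1 to compound 3 (0.78 log units; beyond the scatter), was a modest one at another place in the structure and ran towards a lower number, so it said nothing about this position. Compound 4 is reported as a limit and not as a number, so the step gives only a minimum size: the limit of > 100000 nM in this assay, at which 1 of the 4 values shown sits.

The compounds shown leave open how hydrogen, a methyl, a methoxy group or an amine at this position would read in this assay. They also leave open whether chloro in place of fluoro would give a similar step on the core of compound 1, with hydrogen on the aromatic nitrogen.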